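A Weak Inhibitor Loses Its Acetyl(phenyl)amino Group

The source may report more compounds than this note shows. Statements on the series, on what has been measured and on what is new or still open speak of the compounds shown alone.

In a functional assay (brain) with Canis familiaris (Canis lupus familiaris) as the target (a lower number here means a stronger inhibitor, a higher number a weaker inhibitor), compound 2 `CC(=O)N(CC(O)CN1CCN(CCCC(c2ccc(F)cc2)c2ccc(F)cc2)CC1)c1ccccc1` gives 390000 nM, the highest number of the three measured. Compound 1 `CC(=O)OC(CSc1ccccc1)CN1CCN(CCCC(c2ccc(F)cc2)c2ccc(F)cc2)CC1` gives 20000 nM. Among the measured compounds shown here, the only measured step, a 1.5-fold lower number from compound 1 to compound 3 (0.19 log units; within the scatter), lies within the scatter. Compound 4 `OC(CNCc1ccccc1)CN1CCN(CCCC(c2ccc(F)cc2)c2ccc(F)cc2)CC1` has benzylamino in place of acetyl(phenyl)amino on a saturated chain carbon, two bonds along the chain from an oxygen on a saturated carbon. For the measured compounds named here, no measured step covers this change. Only compound 2 carries acetyl(phenyl)amino, whereas compound 3 `CC(=O)OC(CNc1ccccc1)CN1CCN(CCCC(c2ccc(F)cc2)c2ccc(F)cc2)CC1`, with anilino, gives 13000 nM, so a clear fall is expected in this assay. The expected step is a 9.8-fold lower number from compound 2 to compound 4 (0.99 log units; beyond the scatter). The estimate for compound 4 is 40000 nM, within an expected range of 10000 nM to 160000 nM.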

Compound 4, half-maximal inhibitory concentration: 6900 nM
For compound 4 the middle estimate is 5.8-fold (0.76 log units) above the measured one; measured number below the stated range.
By their numbers in this assay, from the lowest: compounds 4, 3 and 1 (each within the scatter of the next, the first and the last beyond it); then compound 2.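

In this assay, among the compounds shown here, benzylamino in place of acetyl(phenyl)amino gives a 57-fold lower number from compound 2 to compound 4 (1.75 log units; beyond the scatter) and is large, whereas the one earlier step lay within the scatter. This place on the chain, two bonds along from an oxygen on a saturated carbon, can therefore shift the number strongly. No measurement shown accounts for the size of this step.

The swap replaces a whole group, so losing the acetyl and gaining the benzyl cannot be told apart. An acetyl(benzyl)amino group at this place would help separate the two.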